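A few compounds are considered here, and "the series" means these few. Any claim that something is new, unique, unknown or untested is made for them only; others in the source may bear on it.

Working notes on the series. The series shares a common core, shown in compound 1 `COC(=O)C1=C(c2ccc(CNc3nccc(C)c3NC(=O)CC#N)cc2)CCCC1`, and is followed in an assay on isolated protein for binding affinity to B1 bradykinin receptor (Homo sapiens) (a higher number here means a weaker inhibitor, a lower number a stronger inhibitor), where compound 1 gives 35 nM, the lowest of the three numbers recorded so far. Compound 3 `COC(=O)C1C2CCC(C2)C1c1ccc(CNc2nccc(C)c2NC(=O)CC#N)cc1` gives 730 nM in this assay, a higher number than that of compound 1 and beyond the scatter. Compound 2 `COC(=O)c1ccccc1N1CCC(C)(CNc2nccc(C)c2NC(=O)CC#N)CC1`, which carries its methoxycarbonyl group on a different ring arrangement, gives 3500 nM, the highest of the three.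

The next compound, compound 4 `COC(=O)N1CCCCC1c1ccc(CNc2nccc(C)c2NC(=O)CC#N)cc1`, is a single change from compound 1: 1-(methoxycarbonyl)piperidin-2-yl in place of 2-(methoxycarbonyl)cyclohex-1-en-1-yl on an aromatic carbon. For the measured compounds named here, no step between two measured compounds isolates this change, so nothing measured tells how the series reacts to it. The replacement alters both the ring and the point at which the methoxycarbonyl group is attached. Given that the two other arrangements of that group, compounds 2 and 3, gave higher numbers than compound 1, a step upward beyond the scatter is expected, an 8.6-fold higher number from compound 1 to compound 4 (0.93 log units; beyond the scatter). Compound 4 is therefore estimated at 300 nM, with a range from 60 nM to 1500 nM.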

Compound 4, inhibition constant: > 5000 nM
Compound 4: only a limit was reported; the forecaster's own chance of this, stated with the estimate: 5%; middle value at least 16-fold (1.22 log units) from the limit.
By their numbers in this assay, from the lowest: compound 1; then compound 3; then compound 2. At a limit, above all of these: compound 4.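

In this assay compound 4 gives > 5000 nM, which is a limit of the assay and not a number. Placing 1-(methoxycarbonyl)piperidin-2-yl on this aromatic carbon, para to a large group, gives an at least 140-fold higher number from compound 1 to compound 4 (2.15 log units; beyond the scatter), so this position does not accept every six-membered non-aromatic ring that carries a methoxycarbonyl group. For the compounds shown here, the entering ring holds one hetero atom and the group has one double bond outside aromatic rings, against none and two in the group it replaces, and the single step does not separate these differences.

Which of these differences accounts for the step stays open. Also open, as far as these compounds go, is how a carboxylic acid in place of the methoxycarbonyl group of compound 1, or an amine on the same ring, would read in this assay.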